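The source may hold more compounds than are shown below. What is called first, only, known or untested is meant among the compounds shown, and "the series" means these compounds.

Compound 2 `CCC1=C(O)c2c(oc(-c3ccc(C)c(Cl)c3)cc2=O)C(CC)(CC)C1=O` gives 2.15 uM in a functional assay on KBVIN cells (Homo sapiens) for antiproliferative activity, read by sulforhodamine B assay, with a stated time of 3 days (a higher number here means that more compound is needed for the effect, a lower number that less compound is needed), the lower of the two numbers shown, though compound 1 `CCC1=C(O)c2c(oc(-c3ccccc3F)cc2=O)C(CC)(CC)C1=O` with 3.93 uM lies within the scatter of it. Compound 3 `CCC1=C(O)c2c(oc(-c3cc(C)cc(C)c3)cc2=O)C(CC)(CC)C1=O` differs from compound 2 in one place: 3,5-dimethylphenyl in place of 3-chloro-4-methylphenyl on an aromatic carbon. For the measured compounds named here, the only measured step that bears on this, a 1.8-fold lower number from compound 1 to compound 2 (0.26 log units; within the scatter), likewise exchanged one aryl group for another and stayed within the scatter, so the change is expected to give a 1.2-fold higher number from compound 2 to compound 3 (0.07 log units; within the scatter), no step beyond the scatter in either direction. Compound 3 is therefore estimated at 2.5 uM, in a range from 1 uM to 6.5 uM.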

Compound 3, concentration for half-maximal effect: 0.45 uM
Compound 3: middle estimate off by 5.6-fold (0.74 log units), on the high side; measured number below the stated range.
By their numbers in this assay, from the lowest: compound 3; then compounds 2 and 1 (each within the scatter of the next).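

In this assay the exchange of 3-chloro-4-methylphenyl for 3,5-dimethylphenyl gives a 4.8-fold lower number from compound 2 to compound 3 (0.68 log units; beyond the scatter) and the exchange of 2-fluorophenyl for the same group gives an 8.7-fold lower number from compound 1 to compound 3 (0.94 log units; beyond the scatter) and these are the first steps beyond the scatter among the compounds shown. The position thus answers to the aryl group it carries, even between two groups that each hold 8 heavy atoms and one aromatic carbon ring. On these data alone, whether a methoxy group or an amine in place of either methyl would keep this lower number stays open. Nothing given here explains the step.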